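Shortening the long chain of compound 2

This account rests on a few compounds, and the source may have more. Where it says the series, first, only, none or still open, it means among the compounds named here.

Compound 1 (`CCCCCCCCCCOP(=O)(O)OCCSC(=S)N1CCCCCC1`) gives 32900 nM
Compound 2 (`CCCCCCCCCCCCCCCCOP(=O)(O)OCCSC(=S)N1CCN(C)CC1`) gives 95200 nM

In a functional assay on PC-3 cells (Homo sapiens) for inhibition, read by MTT assay, with stated times of 18 h and 4 h (on this read-out higher numbers stand for weaker inhibition and lower numbers for stronger inhibition), compound 1 stands at 32900 nM and compound 2 at 95200 nM as the higher of the two numbers. That makes compound 2 the weaker inhibitor of this pair, and the gap lies beyond the usual scatter. These two compounds differ in more than one place, so their gap cannot be pinned on any single change.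

Compound 3 (`CCCCCCCCCCOP(=O)(O)OCCSC(=S)N1CCN(C)CC1`) has not been measured yet. It comes from compound 2 by shortening the long chain (hydrogen in place of hexyl on a saturated chain carbon, ten or more bonds along the chain from an oxygen on an unsaturated carbon) with hydrogen in place of hexyl on a saturated chain carbon, ten or more bonds along the chain from an oxygen on an unsaturated carbon. Everything else stays as in compound 2.

Among the compounds with values here, compound 3 shares its shorter chain with compound 1, which gives 32900 nM in this assay and is the only guide available. A modest move toward a lower number is therefore expected, an estimated step of a 2.1-fold lower number from compound 2 to compound 3 (0.33 log units; beyond the scatter) that sits near the edge of the scatter. For compound 3 the estimated value is 45000 nM with an expected range of 18000 nM to 110000 nM around it.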

Compound 3, half-maximal inhibitory concentration: 80000 nM
Compound 3: middle estimate off by 1.8-fold (0.25 log units), on the low side; low and high end bracket the measured number.
By their numbers in this assay, from the lowest: compound 1; then compounds 3 and 2 (each within the scatter of the next).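

In this assay, hydrogen in place of hexyl on a saturated chain carbon, ten or more bonds along the chain from an oxygen on an unsaturated carbon, gives a 1.2-fold lower number from compound 2 to compound 3 (0.08 log units; within the scatter), so with 4-methylpiperazin-1-yl on the thiocarbonyl carbon, this cut in the long chain has no effect that can be told from the scatter. The other one-place comparison, 4-methylpiperazin-1-yl in place of azepan-1-yl on a thiocarbonyl carbon, gives a 2.4-fold higher number from compound 1 to compound 3 (0.39 log units; beyond the scatter), a modest step that, with the chain held the same, can be read as belonging to this single change. Of the two differences that separate compound 1 from compound 2, only this exchange of ring groups now shows a step beyond the scatter, and nothing shown here explains why.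

As far as these compounds go, it remains open whether the long chain would matter as little with azepan-1-yl in place, or whether a much shorter chain such as octyl would move the number. The compounds shown also leave open how other groups on the thiocarbonyl carbon, such as morpholin-4-yl or piperidin-1-yl, would compare with azepan-1-yl and 4-methylpiperazin-1-yl.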